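Removing the para-isopropyl from a thiophene-bearing amide

The source may report more compounds than this note shows. Statements on the series, on what has been measured and on what is new or still open speak of the compounds shown alone.

Compound 1 `CCN(Cc1cccs1)C(=O)COc1ccc(C(C)C)cc1` sits second highest of the three numbers measured in an assay on HEK293 cells for agonist activity at transient receptor potential cation channel subfamily M member 8 (Homo sapiens), read by fluorescence and calcium flux, with a stated time of 15 min; a lower number here means that less compound is needed, a higher number that more compound is needed for the effect: compound 1 gives 397 nM, while compound 2 `Cc1ccc(OCC(=O)N(Cc2cccs2)c2nccs2)cc1` gives 2240 nM and compound 3 `Cc1ccc(OCC(=O)N(Cc2cccs2)c2ccccc2)cc1` gives 23 nM. Going by the values given here, the one single-point step on record, a 97-fold lower number from compound 2 to compound 3 (1.99 log units; beyond the scatter), changes the group on the amide nitrogen, not the aromatic ether, so it does not bear on the change studied here. Compound 4 `CCN(Cc1cccs1)C(=O)COc1ccccc1` differs from compound 1 by hydrogen in place of isopropyl on an aromatic carbon. Among the compounds with values here, with no directly comparable step, the expectation rests on compound 1 alone. The isopropyl is expected to matter somewhat, so a modest increase a 2.8-fold higher number from compound 1 to compound 4 (0.44 log units; beyond the scatter) is estimated. Compound 4 is estimated at 1100 nM, within 300 nM to 4000 nM.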

Compound 4, half-maximal effective concentration: 1400 nM
Estimate against measurement, compound 4: 1.3-fold (0.10 log units) below, within the range that was stated.
By their numbers in this assay, from the lowest: compound 3; then compound 1; then compounds 4 and 2 (each within the scatter of the next).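

Replacing the isopropyl with hydrogen gives a 3.5-fold higher number from compound 1 to compound 4 (0.55 log units; beyond the scatter) in this assay. Going by these compounds alone, this is the first direct reading of this position on the aromatic ring, and it shows that the isopropyl counts for something here, though the step is modest rather than large. No measured evidence explains this difference.

The compounds shown leave open whether a different group at this position, such as tert-butyl, chlorine or an amine, would give a lower number than the isopropyl. They also leave open whether the step would keep its size with phenyl on the amide nitrogen in place of ethyl.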